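A few compounds are considered here, and "the series" means these few. Any claim that something is new, unique, unknown or untested is made for them only; others in the source may bear on it.

Measured so far:
compound 1 `Nc1ccc(Nc2nc3ccccc3nc2S(=O)(=O)c2ccccc2)cc1` — 10800 nM
compound 2 `COc1cc(Nc2nc3ccccc3nc2S(=O)(=O)c2ccc(C)cc2)cc(OC)c1` — > 50000 nM

In a functional assay on HCT-116 cells (Homo sapiens) for cytotoxicity, read by MTT assay, with a stated time of 72 h (on this read-out lower numbers stand for stronger inhibition and higher numbers for weaker inhibition), compound 1 gives 10800 nM. Compound 2 reaches only a limit of the assay, > 50000 nM; it sits at the limit of > 50000 nM in this assay, at which 1 of the 2 values shown sits. Compound 3 `Cc1ccc(S(=O)(=O)c2nc3ccccc3nc2Nc2ccc(N)cc2)cc1` carries 4-aminophenyl in place of 3,5-dimethoxyphenyl on a nitrogen on an aromatic ring. Going by the values given here, no measured step covers this change, and compound 3 shares the 4-aminophenyl of compound 1 while differing from it on the sulfonyl side, so no step from compound 1 is inferred. Compound 3 is expected to fall below the limit held by compound 2, giving a step of an at least 4.1-fold lower number from compound 2 to compound 3 (0.61 log units; beyond the scatter). For compound 3 the estimate in this assay is 12000 nM, within 4000 nM to 40000 nM.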

Compound 3, half-maximal inhibitory concentration: 11500 nM
Estimate against measurement, compound 3: 1.0-fold (0.02 log units) above; measured number inside the range.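

In this assay, 4-aminophenyl in place of 3,5-dimethoxyphenyl on a nitrogen on an aromatic ring gives an at least 4.3-fold lower number from compound 2 to compound 3 (0.63 log units; beyond the scatter), a step with only a lower bound on its size. Compound 2 stands at a limit of the assay, not at a number: the limit of > 50000 nM in this assay, at which 1 of the 3 values shown sits. With 4-aminophenyl held, methyl in place of hydrogen on an aromatic carbon gives a 1.1-fold higher number from compound 1 to compound 3 (0.03 log units; within the scatter), so this methyl separates nothing here.

The compounds shown leave open whether the amine or the absence of the two methoxy groups carries the step, and how a hydroxyl or a carboxylic acid in the amine's place would read.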